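The source may report more compounds than this note shows. Statements on the series, on what has been measured and on what is new or still open speak of the compounds shown alone.

Three compounds carry the same core and differ in the group on a saturated ring carbon. Compound 1 `CC1CCN(c2nc(-c3ccccc3)nc3ccccc23)CC1` gives 69% in a functional assay on the whole organism for inhibition, with Rattus norvegicus as the target, read by paw edema, with stated times of 4 days, 1 h and 2 h, at a dose of 100 mg/kg by the oral route; a higher number here means more inhibition at the dose given (going by the name of the read-out), a lower number less inhibition. Compound 2 `CC1CCN(c2nc(-c3ccc(Cl)cc3)nc3ccc(I)cc23)CC1`, which also carries two halogens on its aromatic rings, gives 45.8%. Compound 3 `CCOC(=O)C1CCN(c2nc(-c3ccccc3)nc3ccccc23)CC1` gives 70.3%. On these numbers compound 3 lies within the scatter of compound 1 and beyond the scatter from compound 2, so the two unhalogenated compounds behave alike, while compound 2 sits well apart.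

The next compound, compound 4 `Nc1nnc(C2CCN(c3nc(-c4ccccc4)nc4ccccc34)CC2)s1`, is still to be measured. It differs from compound 3 in one place: 5-amino-1,3,4-thiadiazol-2-yl in place of ethoxycarbonyl on a saturated ring carbon.

Within the data shown here, only one measured step touches the same saturated ring carbon, the change a number 1.3 percentage points higher from compound 1 to compound 3 (within the scatter). That step shows that swapping the group on this carbon between methyl and ethoxycarbonyl left the read-out essentially unchanged. Among the measured compounds shown here, the incoming group here is larger and carries more heteroatoms than either, so its effect is not directly covered, but the one relevant step gives no reason to expect a large move in either direction.

Compound 4 is therefore expected to give about 64%, with a range from 45% to 82%. That estimate implies a step of a number 6.3 percentage points lower from compound 3 to compound 4 (within the scatter), expected to stay within the scatter.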

Compound 4, a percentage reported as inhibition, in the whole organism at one dose (the size of the read-out at that dose, not a potency): 73%
Estimate against measurement, compound 4: 9 percentage points below, within the range that was stated.
By their numbers in this assay, from the lowest: compound 2; then compounds 1, 3 and 4 (each within the scatter of the next).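

Compound 4 puts a five-membered aromatic ring with 3 hetero atoms, 5-amino-1,3,4-thiadiazol-2-yl, on the saturated ring carbon, and this assay shows a number 2.7 percentage points higher from compound 3 to compound 4 (within the scatter) for this exchange with ethoxycarbonyl. Measured against the small methyl group, the same ring gives a number 4 percentage points higher from compound 1 to compound 4 (within the scatter), so methyl, ethoxycarbonyl and this ring cannot be told apart at this one oral dose, even though the ring brings a hydrogen-bond donor that ethoxycarbonyl does not have and the earlier pair had covered neither a ring nor a donor at this carbon. No separate measurement is available to explain why such different groups give matching readings.

From the compounds shown here alone, it remains open whether a carboxylic acid, a simple primary amine or a longer alkyl chain on this carbon would also match these three compounds. It is also open whether the same freedom at this carbon would hold with chlorine and iodine on the aromatic rings, as in compound 2, since only the methyl group is shown in that halogenated series.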